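Ring Opened to Chain: From Compound 2 to Compound 4

The source may report more compounds than this note shows. Statements on the series, on what has been measured and on what is new or still open speak of the compounds shown alone.

Of the compounds shown here, three sharing a related core have been measured. In a functional assay on PC-3 cells (Homo sapiens) for inhibition, read by sulforhodamine B assay, with a stated time of 48 h (a lower number here means a stronger inhibitor of growth, a higher number a weaker inhibitor of growth), compound 1 `COC1=C[C@H](O)[C@H](C/C=C(\C)CC/C=C(\C)C[C@@H]2C[C@@H](C)C(=O)O2)[C@@H](C)C1=O` gives > 30000 nM, which is a limit of the assay and not a number. Compound 2 `COC1=C(OC)[C@H](O)[C@H](C/C=C(\C)CC/C=C(\C)C[C@@H]2C[C@@H](C)C(=O)O2)[C@@H](C)C1=O` likewise reaches only the limit > 30000 nM in this assay. Compound 3 `COC1=CC(=O)C(C/C=C(\C)CC/C=C(\C)CCC=C(C)C)=C(C)C1=O`, with a different core, also stops at the limit > 30000 nM in this assay. Among the compounds with values here, the one step between measured compounds that differ in a single place, a step that the two limits leave unreadable from compound 1 to compound 2, cannot be read because the limit of > 30000 nM in this assay, at which 3 of the 3 values shown sit, covers both of its ends. Within the data shown here, compound 2 therefore stands at the limit, as do the two other values shown; no measured compound has yielded a number.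

Compound 4 `COC1=C(OC)[C@H](O)[C@H](C/C=C(\C)CC/C=C(\C)C[C@H](O)/C=C(\C)CO)[C@@H](C)C1=O` differs from compound 2 by a group of 7 heavy atoms (5 carbon, 2 oxygen; no ring) in place of a group of 7 heavy atoms (5 carbon, 2 oxygen; one five-membered non-aromatic ring with 1 hetero atom), on a saturated chain carbon bound to a double-bonded chain carbon. Among the measured compounds shown here, no measured step follows this kind of change, and the only measured step, a step that the two limits leave unreadable from compound 1 to compound 2, concerns another place and is itself unreadable. With nothing to set a direction, no step beyond the scatter is expected in this assay, and the most likely outcome is again a limit. Compound 4 is estimated at 30000 nM, within 10000 nM to 100000 nM, which would mean an expected step of a number no higher from compound 2 to compound 4 (the limit leaves the size open).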

Compound 4, concentration for 50% growth inhibition: > 30000 nM
Compound 4 was reported as a limit; the forecaster's own chance of this, stated with the estimate: 70%; the middle value sits exactly at the limit.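

Compound 4 adds no readable step: the comparison of compound 2 with compound 4 cannot be read, because both ends rest on the same limit and not on numbers: the limit of > 30000 nM in this assay, at which 4 of the 4 values shown sit. In this assay the compounds shown leave open how far any of them lies from that limit, and which change, if any, would give a measurable value.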